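Swapping an aryl amide for a pivaloyl group on the shared core

The source may hold more compounds than are shown below. What is called first, only, known or untested is meant among the compounds shown, and "the series" means these compounds.

Among the measured compounds shown here, compound 2 `COc1ccc(-c2cn3cc(C4=CCN(C(=O)c5ccc(Cl)cc5)CC4)ccc3n2)cc1OC` is one of two compounds measured in a functional assay on A549 cells (Homo sapiens) for antiproliferative activity, read by MTT assay, with a stated time of 48 h; a higher number here means a weaker inhibitor, a lower number a stronger inhibitor; in this assay compound 2 gives 8970 nM, the higher of the two numbers, while compound 1 `COc1ccc(-c2cn3cc(C4=CCN(S(=O)(=O)CCc5ccccc5)CC4)ccc3n2)cc1OC` gives 7690 nM. For the measured compounds named here, the only step recorded, a 1.2-fold higher number from compound 1 to compound 2 (0.07 log units; within the scatter), exchanged one group on the ring amine nitrogen for another and changed the number little. Compound 3 `COc1ccc(-c2cn3cc(C4=CCN(C(=O)C(C)(C)C)CC4)ccc3n2)cc1OC` keeps the carbonyl on that nitrogen and differs from compound 2 by tert-butyl in place of 4-chlorophenyl on a carbonyl carbon. Going by the values given here, the one available step bears on this change only loosely, since it replaced a different kind of substituent on the same nitrogen; it suggests the nitrogen substituent has a limited effect in this assay. A step of about a 1.1-fold higher number from compound 2 to compound 3 (0.02 log units; within the scatter) is therefore expected, not beyond the scatter in either direction. Compound 3 is estimated at 9500 nM, with a range from 3500 nM to 25000 nM.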

Compound 3, half-maximal inhibitory concentration: 4340 nM
Beside the measured number, compound 3's estimate is 2.2-fold (0.34 log units) above it; measured number inside the range.
By their numbers in this assay, from the lowest: compounds 3, 1 and 2 (each within the scatter of the next, the first and the last beyond it).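

In this assay, keeping the carbonyl on the ring nitrogen and changing only the group on it gave a 2.1-fold lower number from compound 2 to compound 3 (0.32 log units; beyond the scatter). Among the compounds shown here, this is the first step at this position to pass the scatter, so the group on the carbonyl carbon can shift the number even though the earlier exchange on the nitrogen did not, though the shift is modest. The sulfonyl and the tert-butyl amide do not separate, with a 1.8-fold lower number from compound 1 to compound 3 (0.25 log units; within the scatter), and nothing available explains the difference between tert-butyl and 4-chlorophenyl.

From the compounds shown here alone, whether a methyl or a cyclopropyl group on that carbonyl carbon would follow tert-butyl, or an amine-bearing chain would follow 4-chlorophenyl, remains open. Going by these compounds, it is also open whether an unsubstituted phenyl group would give the number of compound 2 or that of compound 3.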